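Losing the ester: what to expect of compound 4

This account rests on a few compounds, and the source may have more. Where it says the series, first, only, none or still open, it means among the compounds named here.

Measured in a functional assay on HL-60 cells (Homo sapiens) for cytotoxicity, read by MTT assay, with a stated time of 72 h; on this read-out lower numbers stand for stronger inhibition and higher numbers for weaker inhibition:
compound 1 `CCC(=O)OC/C=C(\C)C[C@@H](O)[C@@]1(C)[C@H](C)CC=C2[C@@H]1CCCC2(C)C`: > 30000 nM
compound 2 `C/C(=C\COC(=O)c1ccccc1)C[C@@H](O)[C@@]1(C)[C@H](C)CC=C2[C@@H]1CCCC2(C)C`: > 30000 nM
compound 3 `COc1ccc(C(=O)OC/C=C(\C)C[C@@H](O)[C@@]2(C)[C@H](C)CC=C3[C@@H]2CCCC3(C)C)cc1`: > 30000 nM

All three entries are limits of the assay and not numbers. Compound 3 therefore has no exact place on the scale, only its limit of > 30000 nM. The evidence so far comes down to one line: the limit of > 30000 nM in this assay, at which 3 of the 3 values shown sit.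

The next compound, compound 4 `C/C(=C\CO)C[C@@H](O)[C@@]1(C)[C@H](C)CC=C2[C@@H]1CCCC2(C)C`, comes from one structural change: hydrogen in place of (4-methoxyphenyl)carbonyl on an oxygen on a saturated carbon. Put simply, this is hydrogen in place of (4-methoxyphenyl)carbonyl on an oxygen on a saturated carbon.

Among the measured compounds shown here, three measured steps concern this same group: a step that the two limits leave unreadable from compound 1 to compound 2, a step that the two limits leave unreadable from compound 1 to compound 3 and a step that the two limits leave unreadable from compound 2 to compound 3. None of them has a readable size, so they show no trend to carry forward. Ethyl, phenyl and 4-methoxyphenyl on the carbonyl carbon all gave a limit in this assay, and no measured compound lacks the group altogether.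

The starting point is compound 3, with its limit of > 30000 nM, so no clear gain is expected. The estimated change, a step that the limit leaves unreadable from compound 3 to compound 4, has no firm expected direction. Compound 4 is estimated at 40000 nM, with an expected range from 15000 nM to 100000 nM.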

Compound 4, half-maximal inhibitory concentration: > 30000 nM
Compound 4: no number, only a limit; the forecaster's own chance of this, stated with the estimate: 85%; the middle value is on the limit's open side.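

In this assay compound 4 gives > 30000 nM, which is a limit of the assay and not a number. The steps to compound 4 from compound 1, compound 2 and compound 3 therefore cannot be read. The compounds shown leave open how far any of the four lies from this limit, and whether removing the ester changes activity at all.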